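The source may hold more compounds than are shown below. What is called first, only, known or untested is meant among the compounds shown, and "the series" means these compounds.

Working notes on the series. Compound 3 `CCCCCCCCCCc1cn(C[C@H](O)[C@H]2OC(=O)C(OCc3ccccc3)=C2OCc2ccccc2)nn1` gives, in a functional assay on MCF7 cells (Homo sapiens) for antiproliferative activity, read by MTT assay, with a stated time of 72 h (a higher number here means a weaker inhibitor, a lower number a stronger inhibitor), compound 3 a value of 80 nM. Compound 1 `Cc1ccc(-c2cn(C/C=C3\OC(=O)C(OCc4ccccc4)=C3OCc3ccccc3)nn2)cc1` reaches only a limit of this assay, > 100000 nM. Compound 2 `CCCCCc1ccc(-c2cn(C/C=C3\OC(=O)C(OCc4ccccc4)=C3OCc3ccccc3)nn2)cc1` likewise reaches only a limit of this assay, > 100000 nM. Going by the values given here, of the three values shown, compound 3 therefore holds the only number; the other two sit at the limit of > 100000 nM in this assay, at which 2 of the 3 values shown sit. The step that the two limits leave unreadable from compound 1 to compound 2 cannot be read from those two limits. Compound 4 `Cc1ccc(S(=O)(=O)NCc2cn(C[C@H](O)[C@H]3OC(=O)C(OCc4ccccc4)=C3OCc3ccccc3)nn2)cc1` differs from compound 3 by ((4-methylphenyl)sulfonyl)amino in place of nonyl on a saturated chain carbon bound to an aromatic carbon. Among the compounds with values here, no measured step covers this exchange: the single step between measured compounds, a step that the two limits leave unreadable from compound 1 to compound 2, is unreadable, and compounds 1 and 2 differ from compound 3 in more than one place, so they give no direct guide. The expectation therefore rests on compound 3 alone, and a step of a 38-fold higher number from compound 3 to compound 4 (1.57 log units; beyond the scatter) in this assay toward weaker inhibition is estimated, with wide uncertainty in both directions. Compound 4 is expected to give 3000 nM in this assay, with a range from 300 nM to 50000 nM.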

Compound 4, half-maximal inhibitory concentration: 6400 nM
For compound 4 the middle estimate is 2.1-fold (0.33 log units) below the measured one; the range from low to high includes it.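

At the saturated chain carbon bound to an aromatic carbon, ((4-methylphenyl)sulfonyl)amino in place of nonyl gives an 80-fold higher number from compound 3 to compound 4 (1.90 log units; beyond the scatter) in this assay, the first readable measure of how far this place can move the value. The exchange changes several things at once, removing a purely carbon chain and bringing in a six-membered aromatic ring, a hydrogen-bond donor and hydrogen-bond acceptors, yet compound 4 still gives a number, 6400 nM, rather than a limit. Nothing measured in the series accounts for the size of this step.

The compounds shown leave open whether the loss follows from removing the nonyl chain or from the entering sulfonyl amino group. A shorter or longer alkyl chain, a plain phenyl or a primary amine at this place would help separate the two.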